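From Nitro to Trifluoromethyl: Estimating Compound 4

A few compounds are considered here, and "the series" means these few. Any claim that something is new, unique, unknown or untested is made for them only; others in the source may bear on it.

Measured compounds in a functional assay on A549 cells (Homo sapiens) for cytotoxicity, read by resazurin assay, with a stated time of 72 h; a higher number here means a weaker inhibitor, a lower number a stronger inhibitor:
Compound 1 `C#Cn1ccnc1C#Cc1ccc(OC)cc1`: 500 nM
Compound 2 `C#Cn1ccnc1C#Cc1ccccc1`: 6000 nM
Compound 3 `C#Cn1ccnc1C#Cc1ccc([N+](=O)[O-])cc1`: 120 nM

Compound 3 gives the lowest number of the three and is the strongest inhibitor in this set: there is a 4.2-fold lower number from compound 1 to compound 3 (0.62 log units; beyond the scatter) and a 50-fold lower number from compound 2 to compound 3 (1.70 log units; beyond the scatter), both beyond the scatter. Compound 4 `C#Cn1ccnc1C#Cc1ccc(C(F)(F)F)cc1` differs from compound 3 by trifluoromethyl in place of nitro on an aromatic carbon.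

Among the compounds with values here, three measured steps bear on this change, all at the same position on the ring. The substituted compounds both lie well below the unsubstituted one: a 50-fold lower number from compound 2 to compound 3 (1.70 log units; beyond the scatter) and, for the methoxy case, a 12-fold higher number from compound 1 to compound 2 (1.08 log units; beyond the scatter). Between the two substituents themselves the gap is smaller, a 4.2-fold lower number from compound 1 to compound 3 (0.62 log units; beyond the scatter). Within the data shown here, no measured pair shows a trifluoromethyl group, so the size of the step for compound 4 is uncertain; the data only show that a group at this position gives a lower number than hydrogen, with nitro lowest so far. Compound 4 is therefore expected to give a somewhat higher number than compound 3 in this assay, an estimated step of a 2.5-fold higher number from compound 3 to compound 4 (0.40 log units; beyond the scatter), placing it nearer compound 1 than compound 2. The expected value for compound 4 is 300 nM, within a range of 80 nM to 1500 nM.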

Compound 4, half-maximal inhibitory concentration: 6000 nM
Estimate against measurement, compound 4: 20-fold (1.30 log units) below, outside the stated range (above it).
By their numbers in this assay, from the lowest: compound 3; then compound 1; then compounds 2 and 4 (each within the scatter of the next).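

In this assay trifluoromethyl parts from the two other groups at this place on the ring, with no change at the digits printed from compound 2 to compound 4 (within the scatter) and so no gain over hydrogen, which shows that a group here does not by itself give a lower number, as compound 1 and compound 3 alone had suggested. Exchanging nitro for trifluoromethyl gives a 50-fold higher number from compound 3 to compound 4 (1.70 log units; beyond the scatter) and exchanging methoxy for it gives a 12-fold higher number from compound 1 to compound 4 (1.08 log units; beyond the scatter), so among these four compounds the number depends on which group is present and not merely on whether one is. Nothing available accounts for this difference between the groups.

The compounds shown leave open where an amine, a carboxylic acid or a nitrile on the same aromatic carbon would fall. They also leave open whether this order of groups holds on a different core.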